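The compounds below may be only part of what the source reports. "The series", "measured", "known", "first", "only" and "open" are said of these compounds alone.

Compound 3 `CC(C)(C)c1ccc(C(=O)N/N=C/c2cc(I)cc(I)c2O)cc1` gives 41600 nM in a functional assay on HepG2 cells (Homo sapiens) for cytotoxicity, with a stated time of 24 h (on this read-out lower numbers stand for stronger inhibition and higher numbers for weaker inhibition), and stands as the lowest of the two numbers shown. Compound 2 `COc1ccc(C(=O)N/N=C/c2cc(I)cc(I)c2O)cc1` gives 45200 nM in this assay. The step of a 1.1-fold lower number from compound 2 to compound 3 (0.04 log units; within the scatter) separates them. Compound 1 `O=C(N/N=C/c1cc(I)cc(I)c1O)c1ccccc1` gives only a limit in this assay, > 50000 nM. The steps of an at least 1.1-fold lower number from compound 1 to compound 2 (0.04 log units; that floor lies within the scatter) and an at least 1.2-fold lower number from compound 1 to compound 3 (0.07 log units; that floor lies within the scatter) have floors inside the scatter, given (the limit of > 50000 nM in this assay, at which 1 of the 3 values shown sits).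

Compound 4 `O=C(N/N=C/c1cc(I)cc(I)c1O)c1ccc(F)cc1` differs from compound 3 by fluoro in place of tert-butyl on an aromatic carbon. All three measured steps in this assay sit within the scatter, so no step beyond it is expected for compound 4, and the estimated step of a 1.1-fold higher number from compound 3 to compound 4 (0.04 log units; within the scatter) is taken as small. Compound 4 is therefore estimated at 46000 nM in this assay, with an expected range from 25000 nM to 85000 nM.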

Compound 4, half-maximal inhibitory concentration: 12100 nM
The estimate for compound 4 lay 3.8-fold (0.58 log units) above the measured number, outside the stated range (below it).
By their numbers in this assay, from the lowest: compound 4; then compounds 3 and 2 (each within the scatter of the next). At a limit, above all of these: compound 1.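

In this assay, this position first shows a real difference: fluoro gives a 3.4-fold lower number from compound 3 to compound 4 (0.54 log units; beyond the scatter) and a 3.7-fold lower number from compound 2 to compound 4 (0.57 log units; beyond the scatter), whereas tert-butyl and methoxy stay within the scatter of each other. Against hydrogen, only a floor can be read, an at least 4.1-fold lower number from compound 1 to compound 4 (0.61 log units; beyond the scatter), since compound 1 stands at a limit: the limit of > 50000 nM in this assay, at which 1 of the 4 values shown sits. Among the groups shown at this position, fluoro alone gives a number clearly apart from the others.

On these data alone, whether this drop is specific to fluoro remains open, as chloro or an amine here would test that. As far as these compounds go, whether it holds with other changes to the shared core also remains open.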